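The source may hold more compounds than are shown below. What is called first, only, known or untested is meant among the compounds shown, and "the series" means these compounds.

Measured in an assay on microsomes from intestine for inhibition of acyl-CoA:cholesterol acyltransferase (Oryctolagus cuniculus); on this read-out lower numbers stand for stronger inhibition and higher numbers for weaker inhibition:
compound 1 `CC(C)c1cccc(C(C)C)c1NC(=O)NCCC(c1ccccc1)c1ccccc1` gives 140 nM
compound 2 `CC(C)c1cccc(C(C)C)c1NC(=O)NCC1(c2cccnc2)CCCC1` gives 97 nM
compound 3 `COc1ccccc1NC(=O)NCC1(c2ccccc2)CCCCC1` gives 270 nM

Compound 3 stands at the highest of the three numbers in this assay. Its nearest neighbour is compound 1, whose number lies within the scatter of that of compound 3, so the two cannot be ordered against each other. Among the measured compounds shown here, compound 2 lies beyond the scatter, with a lower number than compound 3, and is the only compound that is separated from compound 3 in this way.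

Compound 4 `O=C(NCC1(c2ccccc2)CCCCC1)Nc1ccc(Cl)cc1` differs from compound 3 in a single place: 4-chlorophenyl in place of 2-methoxyphenyl on an amide-type nitrogen. For the measured compounds named here, no measured pair shows this exchange, so its effect has to be guessed. Compounds 1 and 2 share one and the same group on that nitrogen, unlike compound 3, and compound 3 already carries the highest number; the new group in compound 4 resembles none of them. The expected step of a 2.6-fold higher number from compound 3 to compound 4 (0.41 log units; beyond the scatter) in this assay is estimated as a modest move toward a higher number, one that could also stay within the scatter. Compound 4 is therefore expected to come out near 700 nM, with a range from 150 nM to 3000 nM.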

Compound 4, half-maximal inhibitory concentration: 2200 nM
For compound 4 the middle estimate is 3.1-fold (0.50 log units) below the measured one; measured number inside the range.
By their numbers in this assay, from the lowest: compounds 2, 1 and 3 (each within the scatter of the next, the first and the last beyond it); then compound 4.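

In this assay, among the compounds shown here, replacing 2-methoxyphenyl with 4-chlorophenyl on the amide-type nitrogen gives an 8.1-fold higher number from compound 3 to compound 4 (0.91 log units; beyond the scatter) in the first matched pair of the set, showing that inhibition responds strongly to the group at this position. With the rest of the molecule unchanged, the weaker inhibition can be traced to this single exchange, in which a group with one hydrogen-bond acceptor leaves and a group with none enters, although that difference in count is not shown to matter. Nothing available here explains the size of the step.

From the compounds shown here alone, it remains open whether the step comes from losing 2-methoxyphenyl or from gaining 4-chlorophenyl, and an unsubstituted phenyl on the amide-type nitrogen would serve as a reference for both sides of the exchange. Also open, going by these compounds, are how a phenyl bearing an amine or a carboxylic acid would read out in this assay and whether the same exchange would have a comparable effect on the cores of compound 1 and compound 2.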